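This account rests on a few compounds, and the source may have more. Where it says the series, first, only, none or still open, it means among the compounds named here.

Compound 1 `CC(C)(C)C1=CC(=O)C=C(NCC(=O)O)C1=O`: > 200000 nM, a limit of the assay
Compound 2 `CC1=CCC[C@H]2[C@](C)(CC3=CC(=O)C=C(N[C@@H](CC(C)C)C(=O)O)C3=O)[C@@H](C)CC[C@]12C`: 73400 nM
Compound 3 `CC(C)[C@@H](NC1=CC(=O)C=C(C(C)(C)C)C1=O)C(=O)O`: > 200000 nM, a limit of the assay

All three were tested in an ADME assay on MRC5 cells (Homo sapiens) for cytotoxicity, read by MTT assay, with a stated time of 72 h; a lower number here means a stronger inhibitor, a higher number a weaker inhibitor. Within the data shown here, compound 2 is the only one with a true number. Compound 1 and compound 3 show only (the limit of > 200000 nM in this assay, at which 2 of the 3 values shown sit).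

Compound 4 `CC1=CCC[C@H]2[C@](C)(CC3=CC(=O)C=C(N[C@@H](C(=O)O)C(C)C)C3=O)[C@@H](C)CC[C@]12C` keeps the rest of compound 2 and makes one change: 1-carboxy-2-methylpropyl in place of 1-carboxy-3-methylbutyl on an amine nitrogen. Among the measured compounds shown here, the one measured step that bears on this, a step that the two limits leave unreadable from compound 1 to compound 3, has no readable size, so it offers no guide to direction. No change beyond the usual scatter is therefore expected in this assay. The expected step is a 1.0-fold lower number from compound 2 to compound 4 (0.02 log units; within the scatter). Compound 4 is expected at about 70000 nM, with an estimated range of 30000 nM to 160000 nM.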

Compound 4, half-maximal inhibitory concentration: 85400 nM
Estimate against measurement, compound 4: 1.2-fold (0.09 log units) below; the range from low to high includes it.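

Among these compounds, putting 1-carboxy-2-methylpropyl in place of 1-carboxy-3-methylbutyl on the amine nitrogen gives a 1.2-fold higher number from compound 2 to compound 4 (0.07 log units; within the scatter) in this assay, the first readable step at this position. On this shared core, then, the two side chains cannot be told apart in this assay. The earlier step on this nitrogen cannot be read, because both of its compounds sit at a limit: the limit of > 200000 nM in this assay, at which 2 of the 4 values shown sit.

On these data alone, what stays open is whether a different kind of group on this chain, such as an amine, a second carboxylic acid or a phenyl ring, would separate from compound 2.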